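A Methyl for a Trifluoromethoxy Where Only a Limit Stood

This account rests on a few compounds, and the source may have more. Where it says the series, first, only, none or still open, it means among the compounds named here.

Of the compounds shown here, three sharing one core have been measured in a functional assay on T47D cells (Homo sapiens) for cytotoxicity, read by MTT assay, with a stated time of 2 days; on this read-out higher numbers stand for weaker inhibition and lower numbers for stronger inhibition. Compound 1 `Cc1ccc2c(=O)[nH]c(-c3cccc(OC(F)(F)F)c3)nc2c1` gives only a limit there: in this assay compound 1 reads > 50000 nM. Compound 3 `Cc1ccc2nc(-c3ccccc3C(F)(F)F)[nH]c(=O)c2c1` likewise stops at a limit, and in this assay compound 3 reads > 50000 nM. Among the compounds with values here, compound 2 `CCN(CC)c1ccc2nc(-c3cccc4ccccc34)[nH]c(=O)c2c1` is the one with a number: in this assay compound 2 gives 2690 nM. Compound 1 thus sits at the limit of > 50000 nM in this assay, at which 2 of the 3 values shown sit, alongside compound 3, while compound 2 alone shows a measurable value. Within the data shown here, no two of these measured compounds differ in a single place, so no step between them is counted.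

Compound 4 `Cc1cccc(-c2nc3cc(C)ccc3c(=O)[nH]2)c1` is not yet measured. It differs from compound 1 by methyl in place of trifluoromethoxy on an aromatic carbon. Compound 1 offers only a limit, so the size of the step cannot be taken from the measured compounds. Compound 4 is expected to remain at a limit as well, with an estimated step of a number no higher from compound 1 to compound 4 (the limit leaves the size open) not beyond the usual scatter. The estimate for compound 4 is 50000 nM, ranging from 10000 nM to 150000 nM.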

Compound 4, half-maximal inhibitory concentration: > 50000 nM
Compound 4: only a limit was reported (the forecaster's own chance of this, stated with the estimate: 70%); the middle value sits exactly at the limit.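

In this assay compound 4 gives > 50000 nM, a limit and not a number. Within the data shown here, compound 1 also stands at a limit, so no step between compound 1 and compound 4 can be read. The compounds shown leave open whether methyl and trifluoromethoxy differ at all in this assay.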